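A Trifluoromethyl Variant of the Benzyl Side Chain

This account rests on a few compounds, and the source may have more. Where it says the series, first, only, none or still open, it means among the compounds named here.

Compound 3 `O=C(O)c1ccc(F)cc1-c1ccc2c(c1)OC[C@H](CCc1ccccc1)[C@H]2O` carries a benzyl group on the shared core and gives 35 nM in an assay on isolated protein for binding affinity to leukotriene B4 receptor (Homo sapiens); a lower number here means a stronger inhibitor, a higher number a weaker inhibitor. Among the compounds with a single number in this assay it stands lowest: its nearest neighbour is compound 2 `CC(C)c1ccc(C[C@H]2COc3cc(-c4cc(F)ccc4C(=O)O)ccc3[C@@H]2O)cc1`, which gives 190 nM, and the step of a 5.4-fold lower number from compound 2 to compound 3 (0.73 log units; beyond the scatter) lies beyond the scatter. Compound 1 `O=C(O)c1ccc(F)cc1-c1ccc2c(c1)OC[C@H](Cc1ccc(-c3ccccc3)cc1)[C@H]2O` has two entries rather than one number, 4 nM; 14 nM (2 entries), as recorded in the several entries of compound 1 in this assay, 4 nM; 14 nM (2 entries); both of its entries sit below the number of compound 3.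

Compound 4 `O=C(O)c1ccc(F)cc1-c1ccc2c(c1)OC[C@H](Cc1ccc(C(F)(F)F)cc1)[C@H]2O` differs from compound 3 by 4-(trifluoromethyl)phenyl in place of benzyl on a saturated chain carbon bound to a saturated ring carbon. Among the measured compounds shown here, the only measured step at this place is the one from compound 2 to compound 3, where removing a 4-isopropylphenyl in favour of benzyl lowered the number. Compound 4 reverses the direction of that step by placing a substituted phenyl back at the same place, yet with trifluoromethyl rather than isopropyl, and the two entries of compound 1 show that a substituted phenyl at this place can also give low numbers. The size of the change in this assay is therefore expected to be a 1.7-fold higher number from compound 3 to compound 4 (0.23 log units; within the scatter), and compound 4 is estimated at 60 nM, between 15 nM and 250 nM.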

Compound 4, half-maximal inhibitory concentration: 54 nM
For compound 4 the middle estimate is 1.1-fold (0.05 log units) above the measured one, within the range that was stated.
By their numbers in this assay, from the lowest: compounds 3 and 4 (each within the scatter of the next); then compound 2.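

The step to 4-(trifluoromethyl)phenyl on a saturated chain carbon bound to a saturated ring carbon is a 1.5-fold higher number from compound 3 to compound 4 (0.19 log units; within the scatter) in this assay, so a substituted phenyl at this place does not have to bring the number back up to that of compound 2. The earlier step, a 5.4-fold lower number from compound 2 to compound 3 (0.73 log units; beyond the scatter), could have been read as a gain from losing the substituent on the phenyl, but the new comparison on the aromatic carbon, with trifluoromethyl in place of isopropyl, is a 3.5-fold lower number from compound 2 to compound 4 (0.55 log units; beyond the scatter). Among these compounds, then, the identity of the substituent on the phenyl matters and not merely its presence, and compound 1, with a further phenyl there, also gives low numbers: the several entries of compound 1 in this assay, 4 nM; 14 nM (2 entries)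

As far as these compounds go, what an amine or a carboxylic acid on that aromatic carbon would do to the number remains open, as does the effect of a longer chain between the shared core and the phenyl. With only isopropyl, trifluoromethyl and phenyl as substituents in view, the compounds shown do not explain why isopropyl stands apart from the other two.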